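Capping the piperidine urea: dimethyl in place of propyl

The source may report more compounds than this note shows. Statements on the series, on what has been measured and on what is new or still open speak of the compounds shown alone.

Compound 1 `CC(=O)N1CCC(NS(=O)(=O)c2ccc(NC(=O)c3ccccc3C)c3ccccc23)CC1`: 6.7 nM
Compound 2 `CNC(=O)N1CCC(NS(=O)(=O)c2ccc(NC(=O)c3ccccc3C)c3ccccc23)CC1`: 0.7 nM
Compound 3 `CCCNC(=O)N1CCC(NS(=O)(=O)c2ccc(NC(=O)c3ccccc3C)c3ccccc23)CC1`: 77.4 nM

In an assay on L1.2 cells for binding affinity to C-C chemokine receptor type 8 (Homo sapiens) (a higher number here means a weaker inhibitor, a lower number a stronger inhibitor), compound 3 gives 77.4 nM, the highest number of the three; compound 2 sits furthest below it and compound 1 nearest. Compound 4 `Cc1ccccc1C(=O)Nc1ccc(S(=O)(=O)NC2CCN(C(=O)N(C)C)CC2)c2ccccc12` carries dimethylamino in place of propylamino on a carbonyl carbon. Going by the values given here, two measured steps bear on this. The step of a 110-fold higher number from compound 2 to compound 3 (2.04 log units; beyond the scatter) shows that lengthening the chain on the urea nitrogen costs a great deal, while a 9.6-fold lower number from compound 1 to compound 2 (0.98 log units; beyond the scatter) shows that a small nitrogen substituent on the carbonyl carbon is well tolerated. Removing the propyl chain should therefore recover part of that loss, though the donor hydrogen of compound 2 is gone, so a modest rather than full recovery is expected: a 5.2-fold lower number from compound 3 to compound 4 (0.71 log units; beyond the scatter). Compound 4 is estimated at 15 nM, within 3 nM to 80 nM.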

Compound 4, inhibition constant: 1.6 nM
The estimate for compound 4 lay 9.4-fold (0.97 log units) above the measured number, outside the stated range (below it).
By their numbers in this assay, from the lowest: compound 2; then compound 4; then compound 1; then compound 3.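

On this carbonyl carbon, dimethylamino in place of propylamino gives a 48-fold lower number from compound 3 to compound 4 (1.68 log units; beyond the scatter) in this assay and so removes most of the loss seen with the longer chain. The urea also keeps most of its affinity without the hydrogen on that nitrogen, since methyl in its place gives only a 2.3-fold higher number from compound 2 to compound 4 (0.36 log units; beyond the scatter) in this comparison. Dimethylamino also improves on methyl, with a 4.2-fold lower number from compound 1 to compound 4 (0.62 log units; beyond the scatter) as the step.

As far as these compounds go, whether ethylamino or a ring such as pyrrolidine would hold this affinity remains open. Nothing available here explains these differences.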